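This account rests on a few compounds, and the source may have more. Where it says the series, first, only, none or still open, it means among the compounds named here.

Going by the values given here, in a functional assay on T98G cells (Homo sapiens) for inhibition, read by MTT assay, with a stated time of 72 h (on this read-out higher numbers stand for weaker inhibition and lower numbers for stronger inhibition), compound 1 `CC1(C)CC(NC(=S)NCc2ccccc2)c2cc(F)ccc2O1` gives 40000 nM and compound 2 `CC1(C)CC(NC(=O)Nc2cccc(Cl)c2)c2cc(Br)ccc2O1` gives 67000 nM as the only other number so far, and the two lie within the usual scatter of each other. Compound 3 `CC1(C)CC(NC(=S)Nc2ccc(C#N)cc2)c2cc(F)ccc2O1` keeps the core of compound 1 but carries 4-cyanophenyl in place of benzyl on an amide-type nitrogen. Among the compounds with values here, no measured pair of compounds shows what such a change does. The step expected in this assay is therefore none beyond the scatter, with an estimated size of a 1.1-fold lower number from compound 1 to compound 3 (0.06 log units; within the scatter) (a rough expectation). Compound 3 is estimated at 35000 nM (expected range 12000 nM to 90000 nM).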

Compound 3, half-maximal inhibitory concentration: 19000 nM
Compound 3: the middle estimate sits 1.8-fold (0.27 log units) above what was measured; the measured number falls inside the stated range.
By their numbers in this assay, from the lowest: compound 3; then compounds 1 and 2 (each within the scatter of the next).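

Going by these compounds alone, this gives the first measured step at this position, the amide-type nitrogen whose other neighbour is the thiocarbonyl carbon: in this assay, 4-cyanophenyl in place of benzyl gives a modest gain in inhibition (a 2.1-fold lower number from compound 1 to compound 3 (0.32 log units; beyond the scatter)). It is a single pair, so it shows that this nitrogen's substituent can shift the read-out, but not a trend. Nothing measured here explains the shift.

The compounds shown leave open whether the gain comes from the nitrile or from replacing benzyl with a phenyl ring. Plain phenyl or 4-carboxyphenyl on the same nitrogen would help separate these.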